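The source may report more compounds than this note shows. Statements on the series, on what has been measured and on what is new or still open speak of the compounds shown alone.

Working notes on the series. All numbers come from a functional assay on HepG2 cells (Homo sapiens) for antiproliferative activity, read by MTT assay, with a stated time of 24 h; on this read-out higher numbers stand for weaker inhibition and lower numbers for stronger inhibition. Compound 1 `O=c1[nH]cc(S(=O)(=O)Nc2ccccc2-c2cn(-c3ccccc3)nn2)c(=O)[nH]1` gives 6160 nM in this assay. Compound 2 `Cc1cccc(-n2cc(-c3cccc(NS(=O)(=O)c4c[nH]c(=O)[nH]c4=O)c3)nn2)c1` gives 7050 nM in this assay, a value that sits within the scatter of compound 1. Compound 3 `Cc1cccc(-n2cc(-c3ccc(NS(=O)(=O)c4c[nH]c(=O)[nH]c4=O)cc3)nn2)c1` returns in this assay only > 20000 nM, which is a limit of the assay and not a number. Among the numbers shown, compound 3 therefore stands at the weak end, at the limit of > 20000 nM in this assay, at which 1 of the 3 values shown sits, and no step between measured compounds is available to size the move now under consideration.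

The move is 4-fluorophenyl in place of 3-methylphenyl on an aromatic nitrogen, giving compound 4 `O=c1[nH]cc(S(=O)(=O)Nc2ccc(-c3cn(-c4ccc(F)cc4)nn3)cc2)c(=O)[nH]1`. The core, the sulfonamide linkage and the point of attachment of the aryl ring to the triazole are unchanged; only the aryl group on the aromatic nitrogen of the triazole differs. Among the compounds with values here, no measured pair isolates this kind of aryl swap, so its size cannot be read from the data. The expected step is a number no higher from compound 3 to compound 4 (the limit leaves the size open), that is, nothing beyond the scatter, with the result likely again near the limit. Compound 4 is estimated at 20000 nM, within a range from 6000 nM to 60000 nM.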

Compound 4, half-maximal inhibitory concentration: > 20000 nM
Compound 4: a limit, no number; the forecaster's own chance of this, stated with the estimate: 55%; the middle value sits exactly at the limit.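

Compound 4, like compound 3, returns only a limit of the assay and not a number, so no step can be read between the two: the limit of > 20000 nM in this assay, at which 2 of the 4 values shown sit. The compounds shown leave open whether 4-fluorophenyl in place of 3-methylphenyl on an aromatic nitrogen changes the result in this assay at all, and by how much.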